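A few compounds are considered here, and "the series" means these few. Any claim that something is new, unique, unknown or untested is made for them only; others in the source may bear on it.

In an assay for inhibition of Pro-cathepsin H (Homo sapiens), read by fluorescence, tested at 50 uM (on this read-out lower numbers stand for less inhibition and higher numbers for more inhibition at the one concentration tested (going by the name of the read-out)), compound 1 `COc1nc(N[C@H](CCC(=O)O)C(=O)O)nc(OC)n1` gave 0.34%. Compound 2 `O=c1nc(SCc2ccccc2)nc(SCc2ccccc2F)[nH]1` was also entered there, and for compound 2 the result reads "not determined" (no result reported), so it stands nowhere on the numbers shown. Compound 3 `O=c1nc(SCc2ccccc2)nc(SCc2cccc(F)c2)[nH]1` differs from compound 2 in one place: 3-fluorophenyl in place of 2-fluorophenyl on a saturated chain carbon bound to a sulfur. Going by the values given here, no measured step joins these two, and no step of any kind between measured compounds is available, so in this assay no movement beyond the usual scatter can be expected in either direction. Resting only on compound 1 and its 0.34%, the read-out looks low for this series. Compound 3 is therefore estimated to give 5%, within 0% to 25%.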

Compound 3, a percentage reported as inhibition, at one concentration (the size of the read-out at that concentration, not a potency): 4.18%
The estimate for compound 3 lay 0.8 percentage points above the measured number, and the stated range covers the measured number.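

With compound 2 carrying no number in this assay, no step can be read from it to compound 3. Going by these compounds, whether 2-fluorobenzyl and 3-fluorobenzyl differ on this read-out stays open, and no available evidence bears on the result.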